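The source may hold more compounds than are shown below. What is called first, only, known or untested is meant among the compounds shown, and "the series" means these compounds.

Measured compounds:
compound 1 `COc1ccc(OCCCON2C(N)=NC(N)=NC23CCOCC3)cc1` — 11.1 nM
compound 2 `NC1=NC2(CCOCC2)N(OCCCOc2cccc(Cl)c2Cl)C(N)=N1` — "not determined" (no result reported)
compound 3 `NC1=NC2(CCOCC2)N(OCCCOc2ccccc2Cl)C(N)=N1` — "not determined" (no result reported)

The three compounds share one core and differ only in the aryl group at the end of the propyl ether chain. In an assay on isolated protein for inhibition of Dihydrofolate reductase (Homo sapiens), read by spectrophotometry, using NADPH, with stated times of 5 s and 6 min (a higher number here means a weaker inhibitor, a lower number a stronger inhibitor), compound 1 gives 11.1 nM. In this assay compound 2 is recorded as "not determined" (no result reported) and compound 3 as "not determined" (no result reported), so neither carries a number. Among the measured compounds shown here, compound 3 therefore has no place on the scale: the only number in the set belongs to compound 1, and the gap between compound 1 and compound 3 cannot be read from these data.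

Compound 4 `NC1=NC2(CCOCC2)N(OCCCOc2ccc(Cl)cc2Cl)C(N)=N1` is the next member. The change from compound 3 to compound 4 is chloro in place of hydrogen on an aromatic carbon. No comparable step between two measured compounds exists here, so its size cannot be taken from a shown pair. Given that compound 1 already gives 11.1 nM with a different aryl group, the expectation is that compound 4 lands in the same general region, with a step relative to compound 3 that may well stay within the scatter or lean toward a somewhat lower number.

For compound 4 in this assay the estimate is 5 nM, with a range from 1 nM to 25 nM.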

Compound 4, half-maximal inhibitory concentration: 7.46 nM
For compound 4 the middle estimate is 1.5-fold (0.17 log units) below the measured one, within the range that was stated.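

In this assay, 2,4-dichlorophenyl in place of 4-methoxyphenyl on the propyl ether chain gives the step (a 1.5-fold lower number from compound 1 to compound 4 (0.17 log units; within the scatter)), so these two aryl groups cannot be told apart in this assay and a dichlorinated ring at this end of the chain keeps the value in the same range as the methoxy compound. Steps to or from compound 2 and compound 3 cannot be read, as neither carries a number, and the chloro in place of hydrogen, para to a large group and meta to a chloro group, therefore has no measured size of its own. Nothing available here bears on why the two aryl groups give values within the scatter of each other.

With only compound 1 and compound 4 on the scale, the contribution of each single substituent on the aryl ring stays unresolved. Also open, going by these compounds, is whether a carboxylic acid or an amine on the aryl ring, or a longer chain in place of the propyl ether chain, would keep the value in this range.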